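Adding a methyl to compound 3

The source may hold more compounds than are shown below. What is called first, only, known or untested is meant among the compounds shown, and "the series" means these compounds.

Values in a functional assay on HCT-116 cells (Homo sapiens) for inhibition, read by MTT assay, with a stated time of 72 h; on this read-out lower numbers stand for stronger inhibition and higher numbers for weaker inhibition:
Compound 1 `COc1cc2c(Oc3ccc(NC(=O)c4nn(-c5ccccc5C)cc(C)c4=O)cc3)ccnc2cc1OCC(=O)NO`: 9260 nM
Compound 2 `COc1cc2c(Oc3ccc(NC(=O)c4nn(-c5ccccc5C)cc(C)c4=O)cc3)ccnc2cc1OCCCC(=O)NO`: 640 nM
Compound 3 `COc1cc2c(Oc3ccc(NC(=O)c4nn(-c5ccccc5C)ccc4=O)cc3)ccnc2cc1OCCCCCC(=O)NO`: 700 nM

Compound 3 lies within the scatter of compound 2, and the values of both are well under that of compound 1. Compound 4 `COc1cc2c(Oc3ccc(NC(=O)c4nn(-c5ccccc5C)cc(C)c4=O)cc3)ccnc2cc1OCCCCCC(=O)NO` differs from compound 3 by methyl in place of hydrogen on an aromatic carbon. Among the measured compounds shown here, the one measured step, a 14-fold lower number from compound 1 to compound 2 (1.16 log units; beyond the scatter), is large but concerns the chain and not this methyl, so no measurement isolates the change. Compound 2 already carries the methyl and gives 640 nM. In this assay, no step beyond the scatter is therefore expected. The expected step is a 1.1-fold lower number from compound 3 to compound 4 (0.05 log units; within the scatter). Compound 4 is estimated at 620 nM, with an expected range of 250 nM to 1500 nM.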

Compound 4, half-maximal inhibitory concentration: 290 nM
Beside the measured number, compound 4's estimate is 2.1-fold (0.33 log units) above it; the measured number falls inside the stated range.
By their numbers in this assay, from the lowest: compound 4; then compounds 2 and 3 (each within the scatter of the next); then compound 1.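

In this assay, among the compounds shown here, the methyl on the aromatic carbon opposite the ring nitrogen gives a 2.4-fold lower number from compound 3 to compound 4 (0.38 log units; beyond the scatter) and so has a step of its own for the first time. With this methyl in place, the chain still matters beyond the earlier pair, as shown by a 2.2-fold lower number from compound 2 to compound 4 (0.34 log units; beyond the scatter) and by a 32-fold lower number from compound 1 to compound 4 (1.50 log units; beyond the scatter) in the same assay. Nothing available gives a reason for either effect. As far as these compounds go, whether an ethyl or a chlorine at this position would do the same remains open, as does the effect of a longer chain than 4-(hydroxycarbamoyl)butyl.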